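The source may report more compounds than this note shows. Statements on the series, on what has been measured and on what is new or still open speak of the compounds shown alone.

Two macrocyclic compounds built on the same core have been measured in an ADME assay on cells (Homo sapiens) for activation; on this read-out lower numbers stand for higher toxicity in this test and higher numbers for lower toxicity in this test. Compound 1 `COc1ccc2c(OCC[C@@H]3NC(=O)N(C)CCCC/C=C\[C@@H]4C[C@@]4(C(=O)NS(=O)(=O)N4CCC[C@H]4C#N)NC3=O)cc(-c3nc(C(C)C)cs3)nc2c1Cl` gives 28300 nM in this assay. Compound 2 `COc1ccc2c(OCC[C@@H]3NC(=O)N(C)CCCC/C=C\[C@@H]4C[C@@]4(C(=O)NS(=O)(=O)C4(C)CC4)NC3=O)cc(-c3nc(C(C)C)cs3)nc2c1F` gives 57100 nM in this assay; the gap between compound 1 and compound 2 lies within the ordinary scatter of repeated measurements, so the two numbers cannot be told apart with confidence. Of the two numbers shown, that of compound 1 is the lower one, with compound 2 as its only neighbour.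

Compound 3 `COc1ccc2c(OCC[C@@H]3NC(=O)N(C)CCCC/C=C\[C@@H]4C[C@@]4(C(=O)NS(=O)(=O)N4CCOCC4)NC3=O)cc(-c3nc(C(C)C)cs3)nc2c1Cl` has not yet been measured. It differs from compound 1 in one place: morpholin-4-yl in place of 2-cyanopyrrolidin-1-yl on a sulfonyl sulfur. For the measured compounds named here, no step between two measured compounds concerns this group, so there is nothing in the measured pairs to say how the exchange will move the read-out. The rest of the molecule stays the same, and both measured compounds fall in the same broad region of this assay. The step from compound 1 to compound 3 is therefore expected to stay within the usual scatter, a 1.2-fold higher number from compound 1 to compound 3 (0.09 log units; within the scatter), with no firm direction. For compound 3 the estimate in this assay is 35000 nM, with a range from 15000 nM to 80000 nM.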

Compound 3, half-maximal cytotoxic concentration: 26400 nM
Compound 3: middle estimate off by 1.3-fold (0.12 log units), on the high side, within the range that was stated.
By their numbers in this assay, from the lowest: compounds 3, 1 and 2 (each within the scatter of the next, the first and the last beyond it).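

In this assay, replacing 2-cyanopyrrolidin-1-yl with morpholin-4-yl on a sulfonyl sulfur gives a 1.1-fold lower number from compound 1 to compound 3 (0.03 log units; within the scatter) and so leaves compound 1 and compound 3 indistinguishable. For the compounds shown here, this is the first measured step at this position, and it shows that a substantial exchange can occur there without a difference that rises above the scatter: the nitrile, the five-membered ring and the defined stereocentre all leave together, while a six-membered ring containing an oxygen enters. No measurement shown gives a reason for this outcome.

This single pair cannot show what each of those features contributes alone, and it says little about how far the position would tolerate other groups, such as piperazin-1-yl with its free amine, or a chain ending in a carboxylic acid. Compound 2 differs from both compound 1 and compound 3 in more than one place, so its number cannot be assigned to any single group.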